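Swapping the dimethoxyphenyl for a difluorophenyl on the five-membered ring

The compounds below may be only part of what the source reports. "The series", "measured", "known", "first", "only" and "open" are said of these compounds alone.

Compound 1 `COc1ccc(OC)c(C2OC(c3cc(OC)c(OC)c(OC)c3)=NN2C(C)=O)c1`, 0.4% 
Compound 2 `COc1ccc(OC)c(/C=N/NC(=O)c2cc(OC)c(OC)c(OC)c2)c1`, 0.1% 

In a functional assay on BGC-823 cells (Homo sapiens) for antiproliferative activity, read by MTT assay, tested at 1 uM (on this read-out higher numbers stand for a stronger effect at the one concentration tested and lower numbers for a weaker effect), compound 1 gives 0.4%. In this assay compound 2 gives 0.1%. Among the measured compounds shown here, the two numbers sit within the scatter of each other, so compound 1 cannot be set apart from compound 2 on this read-out; both are close to zero, and no step between measured compounds is available to guide a prediction.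

Compound 3 `COc1cc(C2=NN(C(C)=O)C(c3ccc(F)c(F)c3)O2)cc(OC)c1OC` is not yet measured. It differs from compound 1 as follows: 3,4-difluorophenyl in place of 2,5-dimethoxyphenyl on a saturated ring carbon. With nothing in the measured pairs to show the effect of such an exchange, and with both known numbers near zero, no step beyond the scatter is expected from compound 1 to compound 3 in this assay, and the estimated step of a number 2.6 percentage points higher from compound 1 to compound 3 (within the scatter) reflects that. Compound 3 is therefore expected to give about 3%, within a range from 0% to 15%.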

Compound 3, a percentage reported as inhibition, at one concentration (the size of the read-out at that concentration, not a potency): 18.3%
Estimate against measurement, compound 3: 15.3 percentage points below; the whole stated range lies below it.
By their numbers in this assay, from the lowest: compounds 2 and 1 (each within the scatter of the next); then compound 3.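

In this assay, 3,4-difluorophenyl in place of 2,5-dimethoxyphenyl on the saturated ring carbon gives a number 17.9 percentage points higher from compound 1 to compound 3 (beyond the scatter). This is the only step shown that lies beyond the scatter, so the group on this carbon can move the read-out, which compound 1 and compound 2 could not show with numbers that both sit close to zero. No evidence at hand bears on what lies behind this step.

The change removes the methoxy groups and brings in the fluorine atoms in a single exchange, so the compounds shown do not tell which of the two carries the step. Going by these compounds, how an unsubstituted phenyl, a pyridine ring or an aminophenyl group would read on this carbon also remains open.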